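The source may hold more compounds than are shown below. What is called first, only, known or untested is meant among the compounds shown, and "the series" means these compounds.

Of the compounds shown here, three built on one shared core have been tested in a functional assay on MKN-74 cells (Homo sapiens) for antiproliferative activity, with a stated time of 24 h; a higher number here means a weaker inhibitor, a lower number a stronger inhibitor. Compound 1 `NC(=O)c1c(NC(=O)c2ccccc2Cl)sc2c1CCNC2` gives 28700 nM, compound 2 `NC(=O)c1c(NC(=O)c2ccccc2Cl)sc2c1CCN(Cc1ccccc1)C2` gives 14500 nM, and compound 3 `NC(=O)c1c(NC(=O)c2ccccc2Cl)sc2c1CCN(Cc1c(Cl)cccc1Cl)C2` gives 4740 nM, the lowest of the three. They differ only in what sits on the amine nitrogen in the ring: a 2.0-fold lower number from compound 1 to compound 2 (0.30 log units; within the scatter), a 6.1-fold lower number from compound 1 to compound 3 (0.78 log units; beyond the scatter) and a 3.1-fold lower number from compound 2 to compound 3 (0.49 log units; beyond the scatter). Compound 4 `NC(=O)c1c(NC(=O)c2ccccc2Cl)sc2c1CCN(C(=S)Nc1ccccc1)C2` changes that same position again: a group of 9 heavy atoms (7 carbon, 1 nitrogen, 1 sulfur; one six-membered aromatic ring of carbon only) in place of a group of 9 heavy atoms (7 carbon, 2 chlorine; one six-membered aromatic ring of carbon only), on an amine nitrogen in a ring, the entering group bringing one hydrogen-bond donor and one hydrogen-bond acceptor. Going by the values given here, no measured step covers a group of this kind, so its effect is open; the three steps show only modest shifts at this position, so a modest move back upward is expected, as a 2.5-fold higher number from compound 3 to compound 4 (0.40 log units; beyond the scatter). Compound 4 is therefore estimated at 12000 nM, with a range from 4000 nM to 40000 nM.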

Compound 4, half-maximal inhibitory concentration: 15600 nM
Compound 4: the middle estimate sits 1.3-fold (0.11 log units) below what was measured; measured number inside the range.
By their numbers in this assay, from the lowest: compound 3; then compounds 2, 4 and 1 (each within the scatter of the next).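

Swapping the 2,6-dichlorobenzyl group for the group on compound 4, with its hydrogen-bond donor and acceptor, gives a 3.3-fold higher number from compound 3 to compound 4 (0.52 log units; beyond the scatter), so the gain seen with compound 3 does not carry over. The other two comparisons, a 1.1-fold higher number from compound 2 to compound 4 (0.03 log units; within the scatter) and a 1.8-fold lower number from compound 1 to compound 4 (0.26 log units; within the scatter), stay within the scatter. Only compound 3 now lies beyond the scatter of every other compound shown, and no measurement here explains this.

Still open, from the compounds shown here alone, is what a plain chlorobenzyl group would give on this nitrogen, or an oxygen in place of the sulfur of compound 4.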